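The compounds below may be only part of what the source reports. "The series", "measured", "known", "first", "only" and "open" are said of these compounds alone.

Measured so far in a functional assay on HT-1080 cells (Homo sapiens) for cytotoxicity, read by MTT assay, with a stated time of 72 h; a higher number here means a weaker inhibitor, a lower number a stronger inhibitor:
Compound 1 `COc1cccc(/C=C2\CCC/C(=C\c3ccccc3Cl)C2=O)c1OC` gives 11700 nM
Compound 2 `COc1cccc(/C=C2\CCC/C(=C\c3cccc(Cl)c3)C2=O)c1OC` gives 10300 nM
Compound 3 `COc1cccc(/C=C2\CCC/C(=C\c3ccc(Cl)cc3)C2=O)c1OC` gives 11100 nM

These three compounds share one core and differ only in where the chlorine sits on the phenyl ring. Compound 3 stands within the scatter of both other compounds, so these numbers give it no rank of its own. The steps that bear on the next change are those among these three: a 1.1-fold lower number from compound 1 to compound 3 (0.02 log units; within the scatter) and a 1.1-fold higher number from compound 2 to compound 3 (0.03 log units; within the scatter) and a 1.1-fold lower number from compound 1 to compound 2 (0.06 log units; within the scatter) all lie within the scatter. Moving the chlorine has therefore produced no step of measurable size.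

Compound 4 `COc1cccc(/C=C2\CCC/C(=C\c3ccccc3Br)C2=O)c1OC` carries 2-bromophenyl in place of 4-chlorophenyl on a double-bonded chain carbon bound to a double-bonded ring carbon. Its nearest measured relative is compound 1 (11700 nM), which differs from it only in having chlorine where compound 4 has bromine. Within the data shown here, no measured step exchanges one halogen for the other, so that part of the change rests on no data and the range is kept wide. In this assay no step beyond the scatter is expected, and a 1.0-fold lower number from compound 3 to compound 4 (0.00 log units; within the scatter) is the estimate. For compound 4 a value of 11000 nM is expected, within an estimated range of 6000 nM to 20000 nM in all likelihood.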

Compound 4, half-maximal inhibitory concentration: 10800 nM
Beside the measured number, compound 4's estimate is 1.0-fold (0.01 log units) above it; measured number inside the range.
By their numbers in this assay, from the lowest: compounds 2, 4, 3 and 1 (each within the scatter of the next).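

Among these compounds, compound 4 is the first compound here to change the halogen itself rather than its place on the phenyl ring. In this assay, bromo in place of chloro on an aromatic carbon gives only a small step (a 1.1-fold lower number from compound 1 to compound 4 (0.03 log units; within the scatter)), so among these compounds the exchange of one halogen for the other has no measurable effect at this ring position. The two steps that change the halogen and its place together are just as small (a 1.0-fold lower number from compound 3 to compound 4 (0.01 log units; within the scatter) and a 1.0-fold higher number from compound 2 to compound 4 (0.02 log units; within the scatter)), which extends the flat picture set by the chlorine isomers to all four compounds, although nothing in the data explains it.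

All four compounds carry a single chloro or bromo on this phenyl ring, so they leave open whether an amine, a carboxylic acid or a methoxy group in that place would give a step beyond the scatter. They also leave open whether changes elsewhere on the shared core, such as replacing its two methoxy groups with longer alkoxy chains, would shift the number in this assay.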